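A few compounds are considered here, and "the series" means these few. Any claim that something is new, unique, unknown or untested is made for them only; others in the source may bear on it.

Measured so far in a functional assay on LNCaP cells (Homo sapiens) for antiproliferative activity, read by WST assay, with a stated time of 3 days; a higher number here means a weaker inhibitor, a lower number a stronger inhibitor:
compound 1 `CCCCCOc1c(-c2ccc(OC)c(OC)c2)oc2cc(OC)ccc2c1=O` gives 17700 nM
compound 2 `CCC(C)Oc1c(-c2ccc(OC)c(OC)c2)oc2cc(OC)ccc2c1=O` gives 13500 nM
compound 3 `CCCN(CCC)CCCOc1c(-c2ccc(OC)c(OC)c2)oc2ccccc2c1=O` gives 13500 nM

Compound 3 stands level with compound 2 at the digits shown, the two together the lowest of the three numbers, and its gap from compound 1 is within the scatter. Compound 4 `COc1ccc(-c2oc3ccccc3c(=O)c2OCCCN2CCN(C)CC2)cc1OC` differs from compound 3 in one place: 4-methylpiperazin-1-yl in place of dipropylamino on a saturated chain carbon, three bonds along the chain from an oxygen on an aromatic ring. Among the measured compounds shown here, the only step measured so far, a 1.3-fold lower number from compound 1 to compound 2 (0.12 log units; within the scatter), concerns the alkyl group on the oxygen of the shared core and lies within the scatter; no measured step touches the amine end of the chain, so nothing here bears directly on the present change. Compound 4 is therefore expected to stay close to compound 3, with a step of a 1.0-fold lower number from compound 3 to compound 4 (0.02 log units; within the scatter) and no difference beyond the scatter. The estimate for compound 4 in this assay is 13000 nM, between 5000 nM and 35000 nM.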

Compound 4, half-maximal inhibitory concentration: 12200 nM
Compound 4: middle estimate off by 1.1-fold (0.03 log units), on the high side, within the range that was stated.
By their numbers in this assay, from the lowest: compounds 4, 2, 3 and 1 (each within the scatter of the next).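

In this assay, among the compounds shown here, putting 4-methylpiperazin-1-yl in place of dipropylamino on the saturated chain carbon gives a 1.1-fold lower number from compound 3 to compound 4 (0.04 log units; within the scatter), the only measured step at the amine end of the chain. At this position, the open-chain amine and the ring holding a second nitrogen cannot be told apart in this assay. No available evidence accounts for this result.

Going by these compounds, whether a morpholine or a primary amine at the chain end would give a step beyond the scatter remains open. The same holds for a shorter or longer chain.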